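The source may report more compounds than this note shows. Statements on the series, on what has been measured and on what is new or still open speak of the compounds shown alone.

Measured compounds in a functional assay on CHO-K1 cells for agonist activity at Glucose-dependent insulinotropic receptor (Homo sapiens), read by a luciferase reporter, with a stated time of 5 h; a lower number here means that less compound is needed, a higher number that more compound is needed for the effect:

- compound 1, `CC(C)OC(=O)N1CCC(Oc2ncnc3c2CCN3c2ccc(S(C)(=O)=O)cc2F)CC1`: 50.1 nM
- compound 2, `CCCOC(=O)N1CCC(Oc2ncnc3c2CCN3c2ccc(S(C)(=O)=O)cc2F)CC1`: 79.4 nM
- compound 3, `CC(C)COC(=O)N1CCC(Oc2ncnc3c2CCN3c2ccc(S(C)(=O)=O)cc2F)CC1`: 25.1 nM

Compound 3 carries the lowest number of the three. The steps that lead to it are a 2.0-fold lower number from compound 1 to compound 3 (0.30 log units; within the scatter) and a 3.2-fold lower number from compound 2 to compound 3 (0.50 log units; beyond the scatter); the step between the other two is a 1.6-fold higher number from compound 1 to compound 2 (0.20 log units; within the scatter).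

Compound 4, `CCSC(=O)N1CCC(Oc2ncnc3c2CCN3c2ccc(S(C)(=O)=O)cc2F)CC1`, differs from compound 3 in one place: ethylsulfanyl in place of isobutoxy on a carbonyl carbon. For the measured compounds named here, no measured pair exchanges oxygen for sulfur at that carbonyl carbon; the three measured steps only vary the alkyl chain on the oxygen. Those steps were small to modest in size, and the ethylsulfanyl group of compound 4 is shorter than the isobutoxy group of compound 3 while the loss of the branch methyl in compound 2 went with a higher number. The expectation for compound 4 is therefore a step of a 2.8-fold higher number from compound 3 to compound 4 (0.45 log units; beyond the scatter) in this assay, with wide uncertainty. Compound 4 is estimated at 70 nM, within a range of 20 nM to 250 nM.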

Compound 4, half-maximal effective concentration: 31.6 nM
Beside the measured number, compound 4's estimate is 2.2-fold (0.35 log units) above it, within the range that was stated.
By their numbers in this assay, from the lowest: compounds 3, 4, 1 and 2 (each within the scatter of the next, the first and the last beyond it).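

In this assay, ethylsulfanyl on a carbonyl carbon bound to the amide-type nitrogen in a ring is accepted in place of the oxygen-linked chains: the exchange for isobutoxy gives a 1.3-fold higher number from compound 3 to compound 4 (0.10 log units; within the scatter), and the exchange for isopropoxy gives a 1.6-fold lower number from compound 1 to compound 4 (0.20 log units; within the scatter). For the compounds shown here, only the exchange for propoxy goes beyond the scatter, with a 2.5-fold lower number from compound 2 to compound 4 (0.40 log units; beyond the scatter), so the earlier variation of the alkyl chain on oxygen is now joined by a first change to the atom bound to the carbonyl carbon, and here that change does not give a higher number than any of the three oxygen-linked compounds beyond the scatter. No supporting measurement bears on why these numbers fall as they do.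

The compounds shown leave open whether the sulfur or the chain carries this result, a question that ethoxy or isobutylsulfanyl on the same carbonyl carbon would separate. As far as these compounds go, how an ethylamino group would read at this place also remains open.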